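A few compounds are considered here, and "the series" means these few. Any claim that something is new, unique, unknown or untested is made for them only; others in the source may bear on it.

Measured compounds in an assay on cell membranes for displacement of a labelled ligand from corticotropin-releasing factor receptor 1 (Rattus norvegicus); a lower number here means a stronger inhibitor, a higher number a weaker inhibitor:
compound 1, `CCN(CC)c1nc(C)nc2c(-c3cnc(OC)cc3C)c(C)nn12`, 14.5 nM;
compound 2, `CCCN(CCC)c1nc(C)nc2c(-c3ccc(OC)nc3C)c(C)nn12`, 5.7 nM;
compound 3, `CCC(CC)Nc1nc(C)nc2c(-c3ccc(OC)nc3C)c(C)nn12`, 3.1 nM.

Compound 3 has the lowest number of the three, but this carries little weight against compound 2: the step of a 1.8-fold lower number from compound 2 to compound 3 (0.26 log units; within the scatter) lies within the scatter. Only compound 1, with a number beyond the scatter of compound 3, stands clearly apart.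

Compound 4, `CCCC(C)Nc1nc(C)nc2c(-c3ccc(OC)nc3C)c(C)nn12`, is not yet measured. Its difference from compound 3 is 1-methylbutyl in place of pentan-3-yl on a nitrogen on an aromatic ring. Among the compounds with values here, only one measured step touches this place on the shared core, the step of a 1.8-fold lower number from compound 2 to compound 3 (0.26 log units; within the scatter), and it swaps a different group than the one entering here; the two chains in compounds 3 and 4 are alike in size and carry no donors or acceptors. Nothing in the measured data therefore points to a shift beyond the scatter, and the step of a 1.1-fold higher number from compound 3 to compound 4 (0.05 log units; within the scatter) is expected to stay small in either direction. Compound 4 is estimated at 3.5 nM, with a range from 1.5 nM to 9 nM.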

Compound 4, half-maximal inhibitory concentration: 3.5 nM
Compound 4: the middle estimate sits on the measured number at the digits printed; the range from low to high includes it.
By their numbers in this assay, from the lowest: compounds 3, 4 and 2 (each within the scatter of the next); then compound 1.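

In this assay, putting 1-methylbutyl in place of pentan-3-yl, with the same atoms joined differently on the nitrogen, gives a 1.1-fold higher number from compound 3 to compound 4 (0.05 log units; within the scatter) and so shows that this rearrangement of the chain leaves the number within the scatter. Compared with dipropylamino, (1-methylbutyl)amino gives a 1.6-fold lower number from compound 2 to compound 4 (0.21 log units; within the scatter) and, alongside a 1.8-fold lower number from compound 2 to compound 3 (0.26 log units; within the scatter), neither of these secondary amines stands apart from dipropylamino on an aromatic carbon. No supporting evidence bears on why these changes remain so small.

The compounds shown leave open whether a longer chain, a cyclopropylmethyl group or a chain carrying a hydroxyl group on this nitrogen would move the number beyond the scatter. Compound 1 differs from the others in more than one place, so the effect of its diethylamino group cannot be read separately.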